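Trifluoromethyl on the benzyl group of two macrocyclic anilines

The compounds below may be only part of what the source reports. "The series", "measured", "known", "first", "only" and "open" are said of these compounds alone.

Compound 1, `c1ccc(COc2ccc(Nc3ncnc4cc5c(cc34)OCCOCCOCCO5)cc2)cc1`, gives in a functional assay on A549 cells (Homo sapiens) for antiproliferative activity, read by MTT assay, with a stated time of 72 h (on this read-out lower numbers stand for stronger inhibition and higher numbers for weaker inhibition), only a limit, > 100000 nM.
Compound 2, `c1ccc(COc2ccccc2Nc2ncnc3cc4c(cc23)OCCOCCOCCO4)cc1`, gives in this assay 6940 nM.
Compound 3, `FC(F)(F)c1ccc(COc2ccc(Nc3ncnc4cc5c(cc34)OCCOCCOCCO5)cc2)cc1`, gives in this assay 30700 nM.

Compound 1 and compound 2 are built from the same atoms joined differently; the difference between the two cores is not broken down here. Compound 2 has the lowest of the two numbers, with compound 3 the nearest and higher. From compound 1 to compound 3 the change is trifluoromethyl in place of hydrogen on an aromatic carbon, and it produced an at least 3.2-fold lower number from compound 1 to compound 3 (0.51 log units; beyond the scatter), a step whose size is set by the limit of > 100000 nM in this assay, at which 1 of the 3 values shown sits. Compound 4, `FC(F)(F)c1ccc(COc2ccccc2Nc2ncnc3cc4c(cc23)OCCOCCOCCO4)cc1`, has not yet been measured in this assay; it differs from compound 2 by trifluoromethyl in place of hydrogen on an aromatic carbon, the same change. Resting on an at least 3.2-fold lower number from compound 1 to compound 3 (0.51 log units; beyond the scatter), compound 4 is expected to show a 2.8-fold lower number from compound 2 to compound 4 (0.44 log units; beyond the scatter) in this assay. The estimate for compound 4 is 2500 nM, expected to lie between 800 nM and 7000 nM.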

Compound 4, half-maximal inhibitory concentration: > 100000 nM
Compound 4 ended at the assay's limit; the forecaster's own chance of this, stated with the estimate: 5%; middle value at least 40-fold (1.60 log units) away from the limit.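

In this assay, trifluoromethyl in place of hydrogen on an aromatic carbon gave an at least 14-fold higher number from compound 2 to compound 4 (1.15 log units; beyond the scatter), so the change did not carry from one core to the other and its direction reversed: the same change on two cores in this assay, an at least 3.2-fold lower number (0.51 log units; beyond the scatter) from compound 1 to compound 3 and an at least 14-fold higher number (1.15 log units; beyond the scatter) from compound 2 to compound 4, at least 46-fold (1.67 log units) apart, beyond the scatter of two such steps. Compound 1 and compound 4 both stand at a limit, so the full size of neither step is known: the limit of > 100000 nM in this assay, at which 2 of the 4 values shown sit. The two pairs show that the outcome of this change depends on the core, but they do not show what in the cores decides it, nor how it would behave on any further core.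

The compounds shown leave open how a methyl group or a chlorine atom in the same place on the benzyl group would read on each core. They also leave open whether a nitrile there would follow compound 3 or compound 4.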